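Swapping a Double Bond for a Triple Bond

The source may report more compounds than this note shows. Statements on the series, on what has been measured and on what is new or still open speak of the compounds shown alone.

Measured so far:
- Compound 1 `C#CCOc1noc2c1CNCC2`: 7.6
- Compound 2 `C/C=C/COc1noc2c1CNCC2`: 7.7

In a physicochemical assay for acid dissociation, compound 2 gives 7.7, which lies within the usual scatter of compound 1 at 7.6. The two cannot be told apart on these numbers.

The next structure is compound 3 `CC#CCOc1noc2c1CNCC2`: prop-1-yn-1-yl in place of prop-1-en-1-yl on a saturated chain carbon bound to an oxygen on an aromatic ring. Here prop-1-yn-1-yl stands in place of prop-1-en-1-yl on a saturated chain carbon bound to an oxygen on an aromatic ring.

Going by the values given here, one measured step bears on this. Exchanging ethynyl for prop-1-en-1-yl on that kind of carbon gave a number 0.10 log units higher from compound 1 to compound 2 (within the scatter). A swap between a triple-bond group and a double-bond group has thus moved nothing measurable so far, so no shift beyond the scatter is expected here.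

The expected step is a number 0.10 log units lower from compound 2 to compound 3 (within the scatter). For compound 3 the estimate is 7.6, with an expected range from 7.3 to 7.9.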

Compound 3, acid dissociation constant: 7.6
Compound 3: middle estimate and measured number agree at the digits printed; the measured number falls inside the stated range.
By their numbers in this assay, from the lowest: compounds 1, 3 and 2 (each within the scatter of the next).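

Compound 3 gives a direct comparison of a triple bond and a double bond in otherwise matching groups: in this assay, prop-1-yn-1-yl in place of prop-1-en-1-yl gives a number 0.10 log units lower from compound 2 to compound 3 (within the scatter). It also isolates a different change, methyl in place of hydrogen on a triple-bonded carbon, which gives no change at the digits printed from compound 1 to compound 3 (within the scatter). No supporting measurement is available to explain these results.

All three compounds carry an unsaturated carbon chain on the saturated chain carbon bound to an oxygen on an aromatic ring, so these data cannot show whether a fully saturated propyl group or a longer chain would stay within the scatter of these compounds. As far as these compounds go, whether an amine or a carboxylic acid at that place would do the same also remains open.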